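Alkyl urea series: one more carbon on the chain

This account rests on a few compounds, and the source may have more. Where it says the series, first, only, none or still open, it means among the compounds named here.

Measured so far:
compound 1 `CCc1cccc(NC(=O)N[C@H](C)c2ccccc2)c1` 36%
compound 2 `CC(C)c1cccc(NC(=O)N[C@H](C)c2ccccc2)c1` 44%
compound 3 `CCCCCc1ccc(NC(=O)N[C@H](C)c2ccccc2)cc1` 97%

In an ADME assay on the whole organism with Oryza sativa as the target, tested at 10 uM (a higher number here means a weaker effect of the compound at the concentration tested, a lower number a stronger effect), compound 1 gives 36% and compound 2 gives 44%. The two differ by methyl in place of hydrogen on a saturated chain carbon bound to an aromatic carbon and a saturated chain carbon, and the step of a number 8 percentage points higher from compound 1 to compound 2 (within the scatter) is within the scatter, so the two numbers cannot be told apart. Compound 3 stands apart: in this assay compound 3 gives 97%, the highest of the three numbers, and its distance to compound 2 and to compound 1 is in each case beyond the scatter. The difference between the core of compound 3 and the core of compound 1 is not broken down here.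

Compound 4 `CCCCCCc1ccc(NC(=O)N[C@H](C)c2ccccc2)cc1` is not yet measured. It differs from compound 3 by methyl in place of hydrogen on a saturated chain carbon, five bonds along the chain from an aromatic carbon. Within the data shown here, this is the same kind of change as the one from compound 1 to compound 2, but the place is not the same: there the methyl entered on a saturated chain carbon bound to an aromatic carbon and a saturated chain carbon, here it enters on a saturated chain carbon five bonds along the chain from an aromatic carbon. Among the measured compounds shown here, the only measured step of this kind is small, and compound 3 already lies near the top of the scale, so the step from compound 3 to compound 4 is expected to be a number 3 percentage points lower from compound 3 to compound 4 (within the scatter) in this assay. Compound 4 is therefore estimated at 94%, between 80% and 100%.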

Compound 4, a percentage reported as activity, at one concentration (the size of the read-out at that concentration, not a potency): 101%
The estimate for compound 4 lay 7 percentage points below the measured number; the whole stated range lies below it.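

In this assay, methyl in place of hydrogen on a saturated chain carbon, five bonds along the chain from an aromatic carbon, gives a number 4 percentage points higher from compound 3 to compound 4 (within the scatter), so this step shows no readable effect of the extra carbon. Set beside the earlier step, the same change gives no detectable difference between the two cores: the same change on two cores in this assay, a number 8 percentage points higher (within the scatter) from compound 1 to compound 2 and a number 4 percentage points higher (within the scatter) from compound 3 to compound 4, 4 percentage points apart, within the scatter of two such steps This shows only that the change left the read-out within the scatter on both cores; it does not establish a fixed size for the step that can be carried from one core to another, since the methyl enters at a different place on each chain and a step within the scatter has no size that can be read.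

The compounds shown leave open whether a longer chain on the core of compound 3 would also leave the read-out within the scatter, and whether the same change would behave alike at other places on the chain. They also leave open what a hydroxyl group, an amine or a carboxylic acid at the end of the chain would do on either core.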